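This account rests on a few compounds, and the source may have more. Where it says the series, first, only, none or still open, it means among the compounds named here.

Measured so far in a functional assay for inhibition of sodium/hydrogen exchanger (Oryctolagus cuniculus); on this read-out higher numbers stand for weaker inhibition and lower numbers for stronger inhibition:
compound 1 `Cc1c(C(=O)N=C(N)N)cc(S(C)(=O)=O)c(Cl)c1Cl` — 29 nM
compound 2 `Cc1cc(-c2cc(Cl)cc(Cl)c2)c(S(C)(=O)=O)cc1C(=O)N=C(N)N` — 130 nM

Compound 2 carries the higher of the two numbers; compound 1 sits lower by a margin beyond the usual scatter. Among the compounds with values here, only these two values exist, and the two structures differ in more than one place, so no single step between measured compounds can be read off. Compound 3 `Cc1cc(Oc2cccc(Cl)c2)c(S(C)(=O)=O)cc1C(=O)N=C(N)N` is the next entry, not yet measured in this assay. It differs from compound 2 in one place: 3-chlorophenoxy in place of 3,5-dichlorophenyl on an aromatic carbon. Within the data shown here, with no measured step of this kind to anchor the change, the expectation stays close to the starting point. Compound 3 is expected to give 80 nM (range 25 nM to 250 nM) in this assay, which means an expected step of a 1.6-fold lower number from compound 2 to compound 3 (0.21 log units; within the scatter), a shift toward a lower number but not beyond the usual scatter.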

Compound 3, half-maximal inhibitory concentration: 21 nM
Estimate against measurement, compound 3: 3.8-fold (0.58 log units) above; measured number below the stated range.
By their numbers in this assay, from the lowest: compounds 3 and 1 (each within the scatter of the next); then compound 2.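

In this assay, within the data shown here, 3-chlorophenoxy in place of 3,5-dichlorophenyl on the aromatic carbon ortho to a methylsulfonyl group gives a 6.2-fold lower number from compound 2 to compound 3 (0.79 log units; beyond the scatter), the first single-place step, so this position responds to a change of substituent even though the heavy-atom count stays the same. The step combines two edits, with an oxygen entering and one chlorine leaving, and the value alone cannot divide the shift between them. Nothing on hand accounts for the size of the step.

From the compounds shown here alone, whether the shift follows the oxygen or the lost chlorine remains open, and 3-chlorophenyl and 3,5-dichlorophenoxy at this carbon would separate the two. Going by these compounds, how a 3-chlorophenylamino group or a piperidine would behave at the same carbon is also open.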